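A Methylsulfanyl Swap on a Chlorinated Compound

The source may report more compounds than this note shows. Statements on the series, on what has been measured and on what is new or still open speak of the compounds shown alone.

Compound 1 (`C=C1[C@H](n2ccc(=O)[nH]c2=O)O[C@H](CO)[C@H]1O`) reads > 500000 nM as a limit
Compound 2 (`C=C1[C@@H](O)[C@H](n2cnc3c(O)nc(N)nc32)O[C@@H]1CO`) reads > 200000 nM as a limit
Compound 3 (`C=C1[C@H](n2cnc3c(Cl)nc(N)nc32)O[C@H](CO)[C@H]1O`) reads 10000 nM as a measured number

All three compounds were tested in a functional assay on L1210 cells (Mus musculus) for inhibition (a higher number here means a weaker inhibitor, a lower number a stronger inhibitor), and only compound 3 gives an actual number there. Compound 1 stands at a limit of the assay, which is not a number. Compound 2 also stands at a limit of the assay. Compound 3 is therefore the one firm point on this scale.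

Compound 4 (`C=C1[C@H](n2cnc3c(SC)nc(N)nc32)O[C@H](CO)[C@H]1O`) has not yet been measured. It differs from compound 3 in one place, with methylsulfanyl in place of chloro on an aromatic carbon and the rest of the structure unchanged.

Among the compounds with values here, no two measured compounds differ in just one place, so the data give no size for a change of this kind. Within the data shown here, the only anchor is compound 3 at 10000 nM in this series, and the expectation starting from it is a modest move toward weaker inhibition, held with wide uncertainty. The expected change is a 2.5-fold higher number from compound 3 to compound 4 (0.40 log units; beyond the scatter) as an estimate only. In this assay the estimate for compound 4 is 25000 nM with a range from 5000 nM to 150000 nM as the expected bounds.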

Compound 4, half-maximal inhibitory concentration: > 500000 nM
Compound 4 gave a limit, no number (the forecaster's own chance of this, stated with the estimate: 25%); middle value at least 20-fold (1.30 log units) away from the limit.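

In this assay, replacing chloro with methylsulfanyl on this aromatic carbon, with the rest of the structure unchanged, gives an at least 50-fold higher number from compound 3 to compound 4 (1.69 log units; beyond the scatter). Within the data shown here, this is the first direct reading of a change at this position, and it shows that the position is far from indifferent: this one substitution, which adds only a single heavy atom overall, is enough to carry the series from its one firm number to the edge of what the assay can report. Compound 4 stands at a limit, which is not a number, and it shares that limit with compound 1: the limit of > 500000 nM in this assay, at which 2 of the 4 values shown sit.

Going by these compounds, how far compound 4 lies beyond that limit stays unknown, so the step has a lower bound but no upper one. The compounds shown also cannot tell whether the result follows from losing chloro or from bringing in methylsulfanyl, and a methoxy group, a dimethylamino group or a plain hydrogen on the same carbon would be needed to begin separating those two readings.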